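The source may report more compounds than this note shows. Statements on the series, on what has been measured and on what is new or still open speak of the compounds shown alone.

In an ADME assay on microsomes from liver (Homo sapiens) for metabolic stability (on this read-out lower numbers stand for slow clearance and higher numbers for fast clearance), compound 3 (`O=C(N[C@H]1CN(S(=O)(=O)c2ccccc2)C[C@@H]1C(=O)NC[C@@H]1CCCN1)c1cc(-c2ccccc2Cl)on1`) gives 9.7 mL.min-1.g-1 and compound 2 (`O=C(N[C@H]1CN(S(=O)(=O)c2ccccc2)C[C@@H]1C(=O)N1C[C@H]2CCNC[C@H]21)c1cc(-c2ccccc2Cl)on1`) gives 7.3 mL.min-1.g-1. These two values lie within the scatter of each other, with a 1.3-fold higher number from compound 2 to compound 3 (0.12 log units; within the scatter). Compound 1 (`O=C(N[C@H]1CN(S(=O)(=O)c2ccccc2)C[C@@H]1C(=O)N[C@H]1CCCNC1)c1cc(-c2ccccc2Cl)on1`) gives < 3 mL.min-1.g-1, which is a limit of the assay and not a number.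

Compound 4 (`CN(C(=O)[C@H]1CN(S(=O)(=O)c2ccccc2)C[C@@H]1NC(=O)c1cc(-c2ccccc2Cl)on1)[C@H]1CCCNC1`) differs from compound 3 on the carbonyl carbon: a group of 8 heavy atoms (6 carbon, 2 nitrogen; one six-membered non-aromatic ring with 1 hetero atom) in place of a group of 7 heavy atoms (5 carbon, 2 nitrogen; one five-membered non-aromatic ring with 1 hetero atom), on a carbonyl carbon. The entering group holds one six-membered non-aromatic ring with 1 hetero atom, and the matching group in compound 1 holds such a ring too. Read in reverse, an at least 3.2-fold higher number from compound 1 to compound 3 (0.50 log units; beyond the scatter) therefore points towards a lower number for compound 4. Compound 2 goes against this reading, since its group also holds a six-membered non-aromatic ring, yet the data show an at least 2.4-fold higher number from compound 1 to compound 2 (0.38 log units; beyond the scatter). With the two comparisons pulling apart, only a small fall in this assay is expected, not clearly beyond the scatter. The expected step is a 1.6-fold lower number from compound 3 to compound 4 (0.21 log units; within the scatter). Compound 4 is estimated at 6 mL.min-1.g-1, with an expected range from 3 mL.min-1.g-1 to 13 mL.min-1.g-1.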

Compound 4, intrinsic clearance in microsomes: 4.2 mL.min-1.g-1
The estimate for compound 4 lay 1.4-fold (0.15 log units) above the measured number; measured number inside the range.
By their numbers in this assay, from the lowest: compounds 4, 2 and 3 (each within the scatter of the next, the first and the last beyond it). At a limit, below all of these: compound 1.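

In this assay, within the data shown here, the step of a 2.3-fold lower number from compound 3 to compound 4 (0.36 log units; beyond the scatter) gives a change on this carbonyl carbon beyond the scatter with a measured number at both ends, which the earlier steps from compound 1 could give only from a limit. The step of a 1.7-fold lower number from compound 2 to compound 4 (0.24 log units; within the scatter) stays small, so a single six-membered non-aromatic ring with 1 hetero atom does not set this group apart from the group with the four-membered and six-membered rings. Methyl in place of hydrogen on the amide-type nitrogen gives an at least 1.4-fold higher number from compound 1 to compound 4 (0.14 log units; that floor lies within the scatter), and the true size of this step cannot be read because it starts from a limit: the limit of < 3 mL.min-1.g-1 in this assay, at which 1 of the 4 values shown sits.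

Open, going by these compounds, is how an open-chain 2-aminoethyl group or a carboxylic acid on this carbonyl carbon would read. Also open, on these data alone, is whether methyl on the amide-type nitrogen of compound 3 would shift its number.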